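The source may report more compounds than this note shows. Statements on the series, on what has been measured and on what is new or still open speak of the compounds shown alone.

Compound 1 `O=C(CCSc1ccc2c(/C=C/c3ccccn3)n[nH]c2c1)Nc1ccccc1` gives 690 nM
Compound 2 `O=C(CCSc1ccc2c(/C=C/c3ccccn3)n[nH]c2c1)Nc1cccc(F)c1` gives 6590 nM
Compound 3 `O=C(CCSc1ccc2c(/C=C/c3ccccn3)n[nH]c2c1)Nc1ccc(Cl)c(C(F)(F)F)c1` gives > 10000 nM

In an ADME assay on BaF3 cells (Mus musculus) for antiproliferative activity, read by CCK-8 assay, with a stated time of 72 h (on this read-out lower numbers stand for stronger inhibition of growth and higher numbers for weaker inhibition of growth), compound 3 reads > 10000 nM, which is a limit and not a number. Compound 4 `CN(C)CCN(C)Cc1ccc(NC(=O)CCSc2ccc3c(/C=C/c4ccccn4)n[nH]c3c2)cc1C(F)(F)F` carries ((2-(dimethylamino)ethyl)(methyl)amino)methyl in place of chloro on an aromatic carbon. Within the data shown here, the steps that bear on this are a 9.6-fold higher number from compound 1 to compound 2 (0.98 log units; beyond the scatter) and an at least 14-fold higher number from compound 1 to compound 3 (1.16 log units; beyond the scatter), both upward, while an at least 1.5-fold higher number from compound 2 to compound 3 (0.18 log units; that floor lies within the scatter) has a floor within the scatter. None of them tests the entering group, so any forecast is loose. With compound 1 at 690 nM as the only measured anchor that lacks the chloro and trifluoromethyl groups, a partial return downward seems likely. The expected change is an at least 3.3-fold lower number from compound 3 to compound 4 (0.52 log units; beyond the scatter) in this assay. Compound 4 is estimated at 3000 nM, within an expected range from 500 nM to 15000 nM.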

Compound 4, concentration for 50% growth inhibition: 1850 nM
For compound 4 the middle estimate is 1.6-fold (0.21 log units) above the measured one; the range from low to high includes it.
By their numbers in this assay, from the lowest: compound 1; then compound 4; then compound 2. At a limit, above all of these: compound 3.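

In this assay, ((2-(dimethylamino)ethyl)(methyl)amino)methyl in place of chloro, on the aromatic carbon ortho to a trifluoromethyl group, gives an at least 5.4-fold lower number from compound 3 to compound 4 (0.73 log units; beyond the scatter), the only step shown that changes this position alone. This carbon therefore carries a chain of 8 heavy atoms while growth inhibition still reads as a number. Compound 3 stands at a limit and not a number: the limit of > 10000 nM in this assay, at which 1 of the 4 values shown sits.

The compounds shown leave open whether the chain's amine nitrogens matter or the loss of chloro alone accounts for the step. A plain methyl or a morpholinomethyl group on this carbon would separate the two.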